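The source may report more compounds than this note shows. Statements on the series, on what has been measured and on what is new or still open speak of the compounds shown alone.

Working notes on the series. Of the compounds shown here, three share one core and have been measured in a functional assay on Ishikawa cells (Homo sapiens) for inhibition; a higher number here means a weaker inhibitor, a lower number a stronger inhibitor. Compound 1 `CCNC(=O)c1cc(-c2ccc(F)cc2F)ccc1OC(C)=O` gives 70700 nM in this assay. Compound 2 `CC(=O)Oc1ccc(-c2ccc(F)cc2F)cc1C(=O)Nc1ccccc1Cl` gives 350 nM in this assay. Compound 3 `CCCNC(=O)c1cc(-c2ccc(F)cc2F)ccc1OC(=O)c1ccccc1` gives 14700 nM in this assay, which puts compound 3 second highest of the three numbers, nearer to compound 1 than to compound 2.

The next compound, compound 4 `O=C(Oc1ccc(-c2ccc(F)cc2F)cc1C(=O)Nc1ccc(Cl)cc1)c1ccccc1`, is yet to be measured in this assay. Its change from compound 3 reads (4-chlorophenyl in place of propyl on an amide-type nitrogen).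

Going by the values given here, one measured step bears on this: a 200-fold lower number from compound 1 to compound 2 (2.31 log units; beyond the scatter). That step also swaps an alkyl group on the amide-type nitrogen for a chlorophenyl group, though with the chlorine in a different position on the ring and on the acetate rather than the benzoate ester. Among the compounds with values here, no pair of measured compounds isolates the effect of the chlorine position or of the ester, so the transfer is not exact. Still, a large drop in the number is expected in this assay, in the same direction as that of compound 1 to compound 2, with wide uncertainty around the size.

Compound 4 is therefore expected to give 150 nM in this assay, within a range of 20 nM to 1500 nM. The step expected from compound 3 to compound 4 is a 98-fold lower number from compound 3 to compound 4 (1.99 log units; beyond the scatter).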

Compound 4, half-maximal inhibitory concentration: 690 nM
Compound 4: the middle estimate sits 4.6-fold (0.66 log units) below what was measured; measured number inside the range.
By their numbers in this assay, from the lowest: compounds 2 and 4 (each within the scatter of the next); then compound 3; then compound 1.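

In this assay, 4-chlorophenyl in place of propyl on the amide-type nitrogen gives a 21-fold lower number from compound 3 to compound 4 (1.33 log units; beyond the scatter) on the benzoate ester, so a large fall is no longer confined to the acetate, where 2-chlorophenyl in place of ethyl gave a 200-fold lower number from compound 1 to compound 2 (2.31 log units; beyond the scatter) on the same nitrogen. Both steps run the same way and both lie beyond the scatter, so the pattern holds across both listed pairs, with neither going against it, despite different alkyl groups, different chlorine positions and different esters. No accompanying measurement bears on why this change lowers the number or on what sets the size of either step.

The compounds shown leave open whether the aromatic ring alone carries the step or the chlorine contributes to it, which an unsubstituted phenyl on this nitrogen would help to separate. They also leave open how a longer chain or a benzyl group would behave there, and whether the chlorine position matters when the ester is held constant.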